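Methoxycarbonyl to Ethoxycarbonyl: A Small Step Expected

The compounds below may be only part of what the source reports. "The series", "measured", "known", "first", "only" and "open" are said of these compounds alone.

In a functional assay on MCF7 cells (Homo sapiens) for inhibition, read by radiometric assay and XTT assay (a lower number here means a stronger inhibitor, a higher number a weaker inhibitor), compound 1 (`C=CCOC1=CC(=O)S[C@]1(C)CCCCCCCC`) gives 14.5 ug/mL while compound 2 (`C=CCNC(=O)COC1=CC(=O)S[C@]1(C)CCCCCCCC`) gives 12.1 ug/mL and compound 3 (`CCCCCCCC[C@@]1(C)SC(=O)C=C1OC(=O)OC`) gives 21.6 ug/mL on the same scale. These three values lie within the usual scatter of one another, so compound 3 stands level with the other two. Compound 4 (`CCCCCCCC[C@@]1(C)SC(=O)C=C1OC(=O)OCC`) carries ethoxycarbonyl where compound 3 carries methoxycarbonyl, which places methyl in place of hydrogen on a saturated chain carbon bound to an oxygen next to a carbonyl group. Exchanging the whole group on the oxygen on an unsaturated carbon gave the steps of a 1.5-fold higher number from compound 1 to compound 3 (0.17 log units; within the scatter) and a 1.8-fold higher number from compound 2 to compound 3 (0.25 log units; within the scatter) and both stay within the scatter. No step beyond the scatter is therefore expected in this assay here. The expected step is a 1.1-fold lower number from compound 3 to compound 4 (0.03 log units; within the scatter) for this small addition. For compound 4 the estimate is 20 ug/mL with an expected range from 11 ug/mL to 35 ug/mL overall.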

Compound 4, half-maximal inhibitory concentration: 15.1 ug/mL
Compound 4: middle estimate off by 1.3-fold (0.12 log units), on the high side, within the range that was stated.
By their numbers in this assay, from the lowest: compounds 2, 1, 4 and 3 (each within the scatter of the next).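

In this assay, methyl in place of hydrogen on a saturated chain carbon bound to an oxygen next to a carbonyl group gives a 1.4-fold lower number from compound 3 to compound 4 (0.16 log units; within the scatter), so this first change confined to the end of the group leaves compound 4 level with compound 3. Set against the other groups on the oxygen on an unsaturated carbon, ethoxycarbonyl gives a 1.2-fold higher number from compound 2 to compound 4 (0.10 log units; within the scatter) and a 1.0-fold higher number from compound 1 to compound 4 (0.02 log units; within the scatter), so all these exchanges remain within the scatter. No measurement at hand accounts for these small steps. Still open, on these data alone, is whether a longer chain, such as propoxycarbonyl, or an amine at the end of this group would give a step beyond the scatter.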